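Replacing a hydroxy(phenyl)methyl arm with a small ether

The compounds below may be only part of what the source reports. "The series", "measured", "known", "first", "only" and "open" are said of these compounds alone.

Measured compounds:
compound 1 `C[C@@H](c1ccc(Cl)cc1)N1Cc2cncn2C(C[C@@H](O)c2ccccc2)S1(=O)=O`, 234 nM
compound 2 `CC(C)OCC1n2cncc2CN([C@@H](C)c2ccc(Cl)cc2)S1(=O)=O`, 222 nM
compound 3 `C[C@@H](c1ccc(Cl)cc1)N1Cc2cncn2C(C[C@H](O)c2ccccc2)S1(=O)=O`, 182 nM

All three share one core and were tested in an assay on cells for inhibition of cytochrome P450 11B1, mitochondrial (Homo sapiens); a lower number here means a stronger inhibitor, a higher number a weaker inhibitor. Compound 3 stands at the lowest of the three numbers, but the gaps are small: a 1.2-fold lower number from compound 2 to compound 3 (0.09 log units; within the scatter) and a 1.3-fold lower number from compound 1 to compound 3 (0.11 log units; within the scatter) both lie within the scatter, so the three compounds are not separated from one another. The difference between compound 1 and compound 3 is only in how one stereocentre is drawn (the fact that one of compounds 1 and 3 is drawn with a defined configuration and the other without, at the place where they differ).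

Compound 4 `COC(C)(C)CC1n2cncc2CN([C@@H](C)c2ccc(Cl)cc2)S1(=O)=O` has not yet been measured. It differs from compound 3 by 1-methoxy-1-methylethyl in place of hydroxy(phenyl)methyl on a saturated chain carbon bound to a saturated ring carbon. The step that bears most on this change is a 1.2-fold lower number from compound 2 to compound 3 (0.09 log units; within the scatter), where an isopropoxy group took the same place as the hydroxy(phenyl)methyl arm and the number stayed within the scatter; a 1.1-fold lower number from compound 1 to compound 2 (0.02 log units; within the scatter) tells the same story from the other stereoisomer. Swapping the hydroxy(phenyl)methyl arm for a second small ether, 1-methoxy-1-methylethyl, is therefore expected to leave this assay largely unchanged, with a 1.2-fold higher number from compound 3 to compound 4 (0.08 log units; within the scatter).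

Compound 4 is thus estimated at 220 nM in this assay, with a likely range from 110 nM to 450 nM.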

Compound 4, half-maximal inhibitory concentration: 20.6 nM
Compound 4: middle estimate off by 11-fold (1.03 log units), on the high side; measured number outside the range, below it.
By their numbers in this assay, from the lowest: compound 4; then compounds 3, 2 and 1 (each within the scatter of the next).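

Until compound 4, the place on a saturated chain carbon bound to a saturated ring carbon looked indifferent to its substituent in this assay, but 1-methoxy-1-methylethyl there gives an 8.8-fold lower number from compound 3 to compound 4 (0.95 log units; beyond the scatter) and also an 11-fold lower number from compound 1 to compound 4 (1.06 log units; beyond the scatter) against the other drawing of the hydroxy(phenyl)methyl arm. The comparison of the two ethers is the sharpest, with an 11-fold lower number from compound 2 to compound 4 (1.03 log units; beyond the scatter) at the same place, so losing the phenyl ring and the hydroxy group is not enough on its own to produce the gain, as isopropoxy in compound 2 also lacks both and stays within the scatter of compounds 1 and 3. The data given here hold nothing that accounts for the difference between these two ethers.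

The compounds shown leave open whether the gain follows the branched carbon or the methoxy group, a question that a 2-hydroxy-2-methylpropyl or a 2,2-dimethylbutyl arm at this place would address. They also leave open how far the place tolerates a longer chain such as 3-methoxy-3-methylbutyl, or an amine such as a dimethylamino group.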